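Removing One Chloro From Compound 1

The source may hold more compounds than are shown below. What is called first, only, known or untested is meant among the compounds shown, and "the series" means these compounds.

Measured so far:
compound 1 `COc1ccc2cc(C(C)c3nnc4n3N=C(c3ccc(Cl)cc3Cl)CS4)ccc2c1`: 14000 nM
compound 2 `CC(c1ccc(-c2ccccc2)c(F)c1)c1nnc2n1N=C(c1ccc(C(F)(F)F)cc1)CS2`: 6100 nM
compound 3 `CC(c1ccc(-c2ccccc2)c(F)c1)c1n[nH]c(=S)n1N`: "not active" (no number reported)

Of the compounds shown here, three have been tested in a functional assay on HCT-116 cells (Homo sapiens) for inhibition, read by sulforhodamine B assay, with a stated time of 72 h; on this read-out lower numbers stand for stronger inhibition and higher numbers for weaker inhibition. Compound 1 holds the higher of the two reported numbers; compound 2 sits lower by a margin beyond the usual scatter. Compound 3 is reported as not active, with no number given.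

Compound 4 `COc1ccc2cc(C(C)c3nnc4n3N=C(c3ccc(Cl)cc3)CS4)ccc2c1` differs from compound 1 in one place: hydrogen in place of chloro on an aromatic carbon. For the measured compounds named here, no pair of measured compounds that differ in a single place is available, so nothing in the data shows how this change behaves. With only this to go on, the expected step in this assay is small, not clearly beyond the scatter, if anything toward weaker inhibition. Compound 4 is therefore estimated at 16000 nM, within 6000 nM to 45000 nM, which is the expected 1.1-fold higher number from compound 1 to compound 4 (0.06 log units; within the scatter).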

Compound 4, half-maximal inhibitory concentration: 8800 nM
For compound 4 the middle estimate is 1.8-fold (0.26 log units) above the measured one; the measured number falls inside the stated range.
By their numbers in this assay, from the lowest: compounds 2, 4 and 1 (each within the scatter of the next, the first and the last beyond it).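

In this assay, for the compounds shown here, going from 2,4-dichlorophenyl to 4-chlorophenyl gives a 1.6-fold lower number from compound 1 to compound 4 (0.20 log units; within the scatter) for the first pair that differs in one place. This chloro, ortho to a large group, can therefore give way to hydrogen without a shift beyond the scatter. Nothing measured here speaks to the reason for this result.

From the compounds shown here alone, whether a methoxy group or an amine on that same aromatic carbon would behave like hydrogen remains open. So does whether the remaining chloro can also give way to hydrogen with as little effect.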